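Adding a methyl to a coumarin-pyrazole diester

This account rests on a few compounds, and the source may have more. Where it says the series, first, only, none or still open, it means among the compounds named here.

Two compounds share a core in which a coumarin-like fragment is attached to a pyrazole carrying two ethyl ester groups and a phenyl substituent. In a functional assay on DU-145 cells (Homo sapiens) for cytotoxicity, read by MTT assay, with a stated time of 48 h (on this read-out higher numbers stand for weaker inhibition and lower numbers for stronger inhibition), compound 1 `CCOC(=O)c1c(-c2cc3ccccc3oc2=O)nn(-c2cccc(C)c2)c1C(=O)OCC` gives 47000 nM, while compound 2 `CCOC(=O)c1c(-c2cc3ccc(OC)cc3oc2=O)nn(-c2ccccc2)c1C(=O)OCC` gives 33000 nM; the two results sit within the usual scatter of each other, so neither can be called the more potent. Compound 3 `CCOC(=O)c1c(-c2cc3ccc(OC)cc3oc2=O)nn(-c2cccc(C)c2)c1C(=O)OCC` is compound 2 with one change: methyl in place of hydrogen on an aromatic carbon. Among the compounds with values here, no pair of measured compounds isolates exactly this change, but compound 1 already carries the 3-methylphenyl group and its value lies close to that of compound 2, so no movement beyond the scatter is expected, and the step from compound 2 to compound 3 is estimated at a 1.1-fold higher number from compound 2 to compound 3 (0.03 log units; within the scatter) in this assay. Compound 3 is accordingly expected to give about 35000 nM, most likely between 15000 nM and 80000 nM.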

Compound 3, half-maximal inhibitory concentration: 35000 nM
Beside the measured number, compound 3's estimate shows no gap at the digits printed, and the stated range covers the measured number.
By their numbers in this assay, from the lowest: compounds 2, 3 and 1 (each within the scatter of the next).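

In this assay, the change from phenyl to 3-methylphenyl gives a 1.1-fold higher number from compound 2 to compound 3 (0.03 log units; within the scatter), so with the methoxy group present, a methyl meta to a large group leaves the result within the scatter. Compound 3 also isolates the methoxy change, and a 1.3-fold lower number from compound 1 to compound 3 (0.13 log units; within the scatter) likewise stays within the scatter, so neither single change can be told apart from no effect in this cell test. Nothing available here bears on the reason for these results.

Methyl and methoxy are small groups, so it remains open whether an amine, a carboxylic acid or a longer chain such as butyl at the same aromatic carbon would shift the result beyond the scatter. Also open, from the compounds shown here alone, is whether replacing the two ethyl esters of the shared core with carboxylic acids would do so.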